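The source may report more compounds than this note shows. Statements on the series, on what has been measured and on what is new or still open speak of the compounds shown alone.

Measured compounds:
- compound 1 `NS(=O)(=O)c1ccc(C(=O)NNC(=O)c2ccc(F)cc2)cc1`: in an assay on cells for inhibition of Amine oxidase [flavin-containing] B (Homo sapiens), read by fluorescence and spectrophotometry, using microsomes, with a stated time of 20 min (on this read-out lower numbers stand for stronger inhibition and higher numbers for weaker inhibition), compound 1 gives > 100000 nM.
- compound 2 `NS(=O)(=O)c1ccc(-c2nnc(-c3ccc(Cl)cc3)o2)cc1`: in this assay compound 2 gives 48 nM.
- compound 3 `NS(=O)(=O)c1ccc(-c2nnc(-c3ccc(F)cc3)o2)cc1`: in this assay compound 3 gives 79 nM.

The value for compound 1 is a limit of this assay and not a number; it sits at the limit of > 100000 nM in this assay, at which 1 of the 3 values shown sits. Compounds 2 and 3 share one core, compound 1 has another; the difference between the two cores is not broken down here.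

Within the shared core of compounds 2 and 3, the one change is chloro in place of fluoro on an aromatic carbon. This change gives a 1.6-fold lower number from compound 3 to compound 2 (0.22 log units; within the scatter), so the two values stand within the scatter of each other and no order between compound 2 and compound 3 can be read from them.

Compound 4 `NS(=O)(=O)c1ccc(C(=O)NNC(=O)c2ccc(Cl)cc2)cc1` is not yet measured. Going by the values given here, it relates to compound 1 by chloro in place of fluoro on an aromatic carbon, the same change as the one between compound 3 and compound 2, made on the core of compound 1.

Among the compounds with values here, the only measured instance of this change left the read-out essentially unmoved. Compound 1 itself reports no number but a limit. On that basis the step from compound 1 to compound 4 in this assay is expected to be small as well, about a step that the limit leaves unreadable from compound 1 to compound 4. Compound 4 is therefore expected to give about 150000 nM, within a range from 50000 nM to 500000 nM, most likely again reported only as a limit.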

Compound 4, half-maximal inhibitory concentration: 11700 nM
Estimate against measurement, compound 4: 13-fold (1.11 log units) above; measured number outside the range, below it.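

On the core of compound 1, the change from 4-fluorophenyl to 4-chlorophenyl gives an at least 8.5-fold lower number from compound 1 to compound 4 (0.93 log units; beyond the scatter) in this assay, so the change does not keep a single size when carried from one core to the other: the same change on two cores in this assay, a 1.6-fold lower number (0.22 log units; within the scatter) from compound 3 to compound 2 and an at least 8.5-fold lower number (0.93 log units; beyond the scatter) from compound 1 to compound 4, at least 5.1-fold (0.71 log units) apart, beyond the scatter of two such steps. The reading for compound 1, > 100000 nM, is a limit and not a number: the limit of > 100000 nM in this assay, at which 1 of the 4 values shown sits. This does not amount to a rule for the series, as it rests on one pair on each core, no order can be read between compound 2 and compound 3, and nothing here says which feature of the two cores goes with the difference.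

As far as these compounds go, it remains open whether a bromo, a methyl or an amine in the same place on the aromatic ring would also give steps that differ between the two cores, or whether the gap is particular to the pair of fluoro and chloro. It is also open how a carboxylic acid in place of the sulfonamide would read on either core, since every compound shown carries that same group.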